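A few compounds are considered here, and "the series" means these few. Any claim that something is new, unique, unknown or untested is made for them only; others in the source may bear on it.

In a functional assay on Hs-578T cells (Homo sapiens) for cytotoxicity, read by sulforhodamine B assay, with a stated time of 48 h, tested at 1 uM (on this read-out higher numbers stand for a weaker effect at the one concentration tested and lower numbers for a stronger effect), compound 1 `COc1cc(-c2cc(/C=C/C(=O)c3ccc(Cl)c(Cl)c3)[nH]n2)cc(OC)c1OC` gives 104%. Compound 2 `COc1ccc(-c2cc(/C=C/C(=O)c3cc(OC)c(OC)c(OC)c3)[nH]n2)cc1OC` gives 86%. Compound 3 `COc1cc(C(=O)/C=C/c2cc(-c3cc(OC)c(OC)c(OC)c3)n[nH]2)cc(OC)c1OC` gives 80%.

Compound 1 stands highest of the three numbers, and its gaps to compound 2 and to compound 3 are both beyond the scatter, so among these it shows the weakest effect. Compound 4 `COc1cc(-c2cc(/C=C/C(=O)c3ccc(F)c(F)c3)[nH]n2)cc(OC)c1OC` differs from compound 1 in one place: 3,4-difluorophenyl in place of 3,4-dichlorophenyl on a carbonyl carbon. Among the measured compounds shown here, the only measured single step, a number 6 percentage points lower from compound 2 to compound 3 (within the scatter), concerns a methoxy in place of hydrogen on an aromatic carbon and lies within the scatter; it says nothing about a 3,4-difluorophenyl in place of a 3,4-dichlorophenyl. For the measured compounds named here, with no step bearing on this change, no move beyond the scatter in this assay is expected, the expected step being a number 4 percentage points lower from compound 1 to compound 4 (within the scatter). Compound 4 is therefore estimated at 100%, within a range from 85% to 115%.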

Compound 4, a percentage reported as activity, at one concentration (the size of the read-out at that concentration, not a potency): 86%
Beside the measured number, compound 4's estimate is 14 percentage points above it; the range from low to high includes it.
By their numbers in this assay, from the lowest: compounds 3, 2 and 4 (each within the scatter of the next); then compound 1.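

In this assay, putting 3,4-difluorophenyl in place of 3,4-dichlorophenyl on the carbonyl carbon gives a number 18 percentage points lower from compound 1 to compound 4 (beyond the scatter) and so a stronger effect at the one concentration tested. Among the compounds shown here, this is the first sign that the group at this place can move the read-out, since the only earlier step concerned a methoxy in place of hydrogen on an aromatic carbon. Nothing at hand explains the move.

Still open, as far as these compounds go, is whether an unsubstituted phenyl or a phenyl carrying a single fluorine or an amine at this place would give a lower number still. Also open, from the compounds shown here alone, is whether the same change would act alike with the other aromatic groups on the shared core.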